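The source may hold more compounds than are shown below. What is called first, only, known or untested is meant among the compounds shown, and "the series" means these compounds.

Of the compounds shown here, two built on one shared core have so far been tested in a functional assay on MGC-803 cells (Homo sapiens) for inhibition, read by sulforhodamine B assay; a lower number here means a stronger inhibitor, a higher number a weaker inhibitor. Compound 1 `Cc1ccc(NC2=CC(=O)c3nc4n(c3C2=O)[C@H]2OC[C@@H](O)[C@H]2OC4)cc1C` gives 860 nM in this assay. Compound 2 `COc1cccc(NC2=CC(=O)c3nc4n(c3C2=O)[C@H]2OC[C@@H](O)[C@H]2OC4)c1`, which carries a 3-methoxyphenyl in place of the 3,4-dimethylphenyl on the amine nitrogen, gives 1780 nM in this assay; this is the higher of the two numbers, and the swap of aryl groups produced a 2.1-fold higher number from compound 1 to compound 2 (0.32 log units; beyond the scatter).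

Compound 3 `O=C1C=C(Nc2cccc(Cl)c2)C(=O)c2c1nc1n2[C@H]2OC[C@@H](O)[C@H]2OC1` has not yet been measured. It differs from compound 2 by chloro in place of methoxy on an aromatic carbon. Among the measured compounds shown here, no measured pair shows what this particular exchange does: the only known step replaces the whole aryl group rather than one substituent, and even that step was modest. The data therefore give no reason to expect a large move in either direction. Compound 3 is expected to show about 1500 nM in this assay, with a plausible range from 600 nM to 4000 nM. This estimate amounts to a 1.2-fold lower number from compound 2 to compound 3 (0.07 log units; within the scatter), a step expected to stay within the usual scatter.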

Compound 3, half-maximal inhibitory concentration: 1770 nM
Compound 3: middle estimate off by 1.2-fold (0.07 log units), on the low side, and the stated range covers the measured number.
By their numbers in this assay, from the lowest: compound 1; then compounds 3 and 2 (each within the scatter of the next).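

At this place on the aromatic ring, meta to a large group, this assay shows chloro in place of methoxy giving a 1.0-fold lower number from compound 2 to compound 3 (0.00 log units; within the scatter), so the exchange leaves no readable difference, even though it removes a heavy atom and the one hydrogen-bond acceptor of the methoxy. Replacing the 3,4-dimethylphenyl with 3-chlorophenyl gives a 2.1-fold higher number from compound 1 to compound 3 (0.31 log units; beyond the scatter), and replacing it with 3-methoxyphenyl gave a 2.1-fold higher number from compound 1 to compound 2 (0.32 log units; beyond the scatter), so across these three compounds both aryl groups with a single substituent give higher numbers than the 3,4-dimethylphenyl. Nothing shown here explains why methoxy and chloro read alike in this assay.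

Still open, going by these compounds, is what a 3-methylphenyl or a 4-methylphenyl on the same amine nitrogen would give, which would tell whether the lower number of compound 1 goes with one methyl or needs both. Also open, on these data alone, is whether this place stays as insensitive to groups of another kind, such as an amine or a carboxylic acid in place of the chloro.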